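The source may hold more compounds than are shown below. What is called first, only, known or untested is meant among the compounds shown, and "the series" means these compounds.

Measured so far:
Compound 1, `Nc1scc(CN2CCN(c3ccc([N+](=O)[O-])cc3)CC2)c1C(=O)c1ccc(Cl)cc1`: 1%
Compound 2, `Nc1scc(CN2CCN(C3CCCCCC3)CC2)c1C(=O)c1ccc(Cl)cc1`: 0%

Both numbers come from an assay on CHO cells for displacement of a labelled ligand from adenosine receptor A1 (Homo sapiens), read by scintillation counting, with a stated time of 120 min, tested at 10 uM; a higher number here means more inhibition at the concentration tested (going by the name of the read-out), a lower number less inhibition. Among the measured compounds shown here, compound 2 stands lowest of the two numbers, and its nearest neighbour is compound 1, which in this assay gives 1%; the single measured step is a number 1 percentage points lower from compound 1 to compound 2 (within the scatter), brought about by cycloheptyl in place of 4-nitrophenyl on an amine nitrogen in a ring. Both measured compounds thus sit at the bottom of the scale in this assay, and no ordering between them can be read from the data.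

The next compound, compound 3, `Nc1scc(CN2CCN(c3c(F)cc(F)cc3F)CC2)c1C(=O)c1ccc(Cl)cc1`, differs from compound 2 by 2,4,6-trifluorophenyl in place of cycloheptyl on an amine nitrogen in a ring. For the measured compounds named here, the only measured step that touches this position is a number 1 percentage points lower from compound 1 to compound 2 (within the scatter), and it lay within the scatter even though an aromatic group was swapped for a saturated ring. On that basis, no step beyond the scatter is expected for compound 3, a number 2 percentage points higher from compound 2 to compound 3 (within the scatter). The estimated inhibition for compound 3 in this assay is 2%, with a range from -8% to 14%.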

Compound 3, a percentage reported as inhibition, at one concentration (the size of the read-out at that concentration, not a potency): 0%
The estimate for compound 3 lay 2 percentage points above the measured number; the measured number falls inside the stated range.
By their numbers in this assay, from the lowest: compounds 2, 3 and 1 (each within the scatter of the next).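

In this assay, 2,4,6-trifluorophenyl in place of cycloheptyl on the amine nitrogen in the ring gave no change at the digits printed from compound 2 to compound 3 (within the scatter) and, in place of 4-nitrophenyl, gave a number 1 percentage points lower from compound 1 to compound 3 (within the scatter) in the same read-out. Among the compounds shown here, the earlier pair had set only one aromatic group against one saturated ring, whereas this result adds a second aromatic group, one carrying fluorine instead of a nitro group, and it too stays at the bottom of the scale, so the three groups at this position cannot be told apart. Nothing available explains this flat result.

The compounds shown leave open whether any other group on this nitrogen, such as a benzyl group, a pyridine ring or a short alkyl chain, would lift the number off the bottom of the scale in this assay. They also leave open whether this position has any influence on the read-out, as numbers this low could not show a further loss of inhibition.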